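This account rests on a few compounds, and the source may have more. Where it says the series, first, only, none or still open, it means among the compounds named here.

Series notes. Compound 1 `O=C(N/N=C/c1ccco1)c1cc(-c2ccccc2)nn1Cc1ccccc1` has in a functional assay on A549 cells (Homo sapiens) for cytotoxicity, read by MTT assay, with a stated time of 96 h (a lower number here means a stronger inhibitor, a higher number a weaker inhibitor), the entry "not determined" (no result reported); no single number was reported for it. Compound 2 `O=C(N/N=C/c1ccco1)c1cc(-c2ccccc2)nn1Cc1ccc(Cl)nc1`, carrying the same core, gives in this assay a value of 26100 nM, which is the only measured point in the set. Compound 3 `O=C(N/N=C/c1ccccc1O)c1cc(-c2ccccc2)nn1Cc1ccccc1` is still to be measured. The change from compound 1 to compound 3 is 2-hydroxyphenyl in place of furan-2-yl on a carbon with a double bond to nitrogen. Within the data shown here, with no measured step on this core, the direction and size of the change in this assay cannot be read from the data; no step beyond the scatter is assumed either way. For compound 3 the expected value in this assay is 20000 nM, with an estimated range from 5000 nM to 80000 nM.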

Compound 3, half-maximal inhibitory concentration: 10800 nM
Compound 3: the middle estimate sits 1.9-fold (0.27 log units) above what was measured; low and high end bracket the measured number.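

In this assay, among these compounds, compound 3 gives 10800 nM while compound 1 has no single number, so no step between compound 1 and compound 3 can be read. As far as these compounds go, the effect of 2-hydroxyphenyl in place of furan-2-yl on the shared core stays open, and no supporting evidence bears on this result.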